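The compounds below may be only part of what the source reports. "The series", "measured", "known", "first", "only" and "open" are said of these compounds alone.

Of the compounds shown here, three sharing one core have been measured in an ADME assay on NIH3T3 cells (Mus musculus) for cytotoxicity, read by MTT assay, with a stated time of 24 h; on this read-out lower numbers stand for stronger inhibition and higher numbers for weaker inhibition. Compound 1 `O=C(CSc1nnc(-c2ccncc2)o1)N/N=C/c1ccc([N+](=O)[O-])cc1` gives 195000 nM. Compound 2 `COc1ccc(/C=N/NC(=O)CSc2nnc(-c3ccncc3)o2)cc1` gives 132000 nM. Compound 3 `O=C(CSc1nnc(-c2ccncc2)o1)N/N=C/c1ccccc1[N+](=O)[O-]` gives 214000 nM, a number that lies within the scatter of both other compounds. The step to compound 4 `O=C(CSc1nnc(-c2ccncc2)o1)N/N=C/c1cc(Cl)cc(Cl)c1O` is 3,5-dichloro-2-hydroxyphenyl in place of 2-nitrophenyl on a carbon with a double bond to nitrogen. The two measured steps that exchange the ring on the carbon with a double bond to nitrogen, a 1.1-fold higher number from compound 1 to compound 3 (0.04 log units; within the scatter) and a 1.6-fold higher number from compound 2 to compound 3 (0.21 log units; within the scatter), both stayed within the scatter, and a 1.5-fold lower number from compound 1 to compound 2 (0.17 log units; within the scatter) did as well. In this assay no shift beyond the scatter is therefore expected, and the step is estimated as a 1.1-fold lower number from compound 3 to compound 4 (0.03 log units; within the scatter). Compound 4 is expected to give about 200000 nM, between 100000 nM and 400000 nM.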

Compound 4, half-maximal inhibitory concentration: 171000 nM
For compound 4 the middle estimate is 1.2-fold (0.07 log units) above the measured one; the measured number falls inside the stated range.
By their numbers in this assay, from the lowest: compounds 2, 4, 1 and 3 (each within the scatter of the next).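

In this assay, 3,5-dichloro-2-hydroxyphenyl on the carbon with a double bond to nitrogen stays within the scatter of all three earlier rings (a 1.3-fold lower number from compound 3 to compound 4 (0.10 log units; within the scatter); a 1.3-fold higher number from compound 2 to compound 4 (0.11 log units; within the scatter); a 1.1-fold lower number from compound 1 to compound 4 (0.06 log units; within the scatter)). This ring brings chlorine and a hydrogen-bond donor to the position, and neither comes with a shift beyond the scatter among these four compounds. No supporting evidence bears on this result. The compounds shown leave open whether this position responds to a group other than a substituted phenyl ring, such as an amine or a carboxylic acid on a longer chain.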